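Expected tolerance after the change to (trifluoromethyl)sulfonyl

The source may report more compounds than this note shows. Statements on the series, on what has been measured and on what is new or still open speak of the compounds shown alone.

In an ADME assay on Huh7.5.1 cells (Homo sapiens) for cytotoxicity, read by WST assay, with a stated time of 48 h (a higher number here means that more compound is tolerated, a lower number that less compound is tolerated), compound 1 `Cc1c(-c2ccc(Cc3ccc(C(C)(O)C(F)(F)F)cc3)cc2)[nH]c2cccc(F)c2c1=O` gives > 2500 nM, which is a limit and not a number. Compound 2 `Cc1c(-c2ccc(Cc3ccc([S+]([O-])C(F)(F)F)cc3)cc2)[nH]c2cccc(F)c2c1=O` gives > 5000 nM, also a limit and not a number, so its exact standing cannot be read. Compound 3 `Cc1c(-c2ccc(Cc3ccc(S(=O)(=O)C(F)(F)F)cc3)cc2)[nH]c2cccc(F)c2c1=O` has yet to be measured. Its difference from compound 2 is a group of 7 heavy atoms (1 carbon, 2 oxygen, 3 fluorine, 1 sulfur; no ring) in place of a group of 6 heavy atoms (1 carbon, 1 oxygen, 3 fluorine, 1 sulfur; no ring), on an aromatic carbon, with (trifluoromethyl)sulfonyl entering para to a large group on a six-membered aromatic ring of carbon only. One measured step changes the same place, a step that the two limits leave unreadable from compound 1 to compound 2, and it provides no size to carry forward. The reasoning therefore rests on compound 2 and its limit of > 5000 nM as the nearest reference. No step beyond the usual scatter, and no direction, is expected in this assay. The estimated step runs a step that the limit leaves unreadable from compound 2 to compound 3 and is expected to remain within that scatter. Compound 3 is expected to give 7000 nM, with an estimated range from 2500 nM to 20000 nM, and a report as a limit is the likeliest outcome.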

Compound 3, half-maximal cytotoxic concentration: > 2500 nM
Compound 3: a limit, no number; the forecaster's own chance of this, stated with the estimate: 80%; the middle value is on the limit's open side.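

Within the data shown here, compound 1, compound 2 and compound 3 all carry limits and not numbers in this assay, and no step between them can be read. Open, on these data alone, are the half-maximal cytotoxic concentration of each compound and whether (trifluoromethyl)sulfonyl differs at all from the groups it replaces at that place.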